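The source may hold more compounds than are shown below. What is called first, only, known or untested is meant among the compounds shown, and "the series" means these compounds.

Measured compounds: compound 1 `CCOC(=O)c1oc2ccc(NS(=O)(=O)c3ccccc3C)cc2c1C` with 53400 nM in a functional assay on MDA-MB-468 cells (Homo sapiens) for antiproliferative activity, read by MTT assay, with a stated time of 72 h; on this read-out lower numbers stand for stronger inhibition and higher numbers for weaker inhibition; compound 2 `CCOC(=O)c1oc2ccc(NS(=O)(=O)c3ccccc3Cl)cc2c1C` with 137000 nM; compound 3 `CCOC(=O)c1oc2ccc(NS(=O)(=O)c3ccc(Br)cc3)cc2c1C` with 26400 nM.

Compound 3 gives the lowest number of the three: a 2.0-fold lower number from compound 1 to compound 3 (0.31 log units; beyond the scatter), and a 5.2-fold lower number from compound 2 to compound 3 (0.72 log units; beyond the scatter). Compound 4 `CCOC(=O)c1oc2ccc(NS(=O)(=O)c3cccc([N+](=O)[O-])c3)cc2c1C` differs from compound 3 in one place: 3-nitrophenyl in place of 4-bromophenyl on a sulfonyl sulfur. The two steps that bear on this change, a 2.0-fold lower number from compound 1 to compound 3 (0.31 log units; beyond the scatter) and a 5.2-fold lower number from compound 2 to compound 3 (0.72 log units; beyond the scatter), both alter the aryl group on the sulfonyl sulfur, and both are modest in size. Since compound 3 already holds the lowest number, and the aryl variations seen so far move the number only modestly, compound 4 is expected to show a modest rise: a 1.7-fold higher number from compound 3 to compound 4 (0.23 log units; within the scatter). The estimate for compound 4 is 45000 nM, with a range from 15000 nM to 150000 nM.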

Compound 4, half-maximal inhibitory concentration: 30100 nM
Beside the measured number, compound 4's estimate is 1.5-fold (0.17 log units) above it; low and high end bracket the measured number.
By their numbers in this assay, from the lowest: compounds 3, 4 and 1 (each within the scatter of the next, the first and the last beyond it); then compound 2.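

In this assay, 3-nitrophenyl in place of 4-bromophenyl on the sulfonyl sulfur gives a 1.1-fold higher number from compound 3 to compound 4 (0.06 log units; within the scatter), so this swap, which brings in hydrogen-bond acceptors, leaves the number within the scatter. The same group in place of 2-methylphenyl gives a 1.8-fold lower number from compound 1 to compound 4 (0.25 log units; within the scatter), and in place of 2-chlorophenyl it gives a 4.6-fold lower number from compound 2 to compound 4 (0.66 log units; beyond the scatter), so among these four compounds only compound 2 stands clearly apart from compound 3 and compound 4. Nothing available explains these results. The compounds shown leave open how an amine or a carboxylic acid on this aryl group would read.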